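From 5-methylfuran-2-yl to 4-methylphenyl on a shared core

The source may hold more compounds than are shown below. What is called first, only, known or untested is meant among the compounds shown, and "the series" means these compounds.

Compound 3 (`Cc1ccc(-c2cc(-c3ccc(Cl)o3)cc(-c3ccsc3)n2)o1`) gives > 50000 nM in a functional assay on HeLa cells (Homo sapiens) for cytotoxicity, in the presence of a further agent that is not named here (on this read-out higher numbers stand for weaker inhibition and lower numbers for stronger inhibition), which is a limit and not a number. Compound 1 (`Clc1ccc(-c2cc(-c3ccsc3)nc(-c3ccco3)c2)o1`) gives > 50000 nM, which is also a limit. Together these two compounds account for (the limit of > 50000 nM in this assay, at which 2 of the 3 values shown sit). Compound 2 (`Clc1ccc(-c2cc(-c3ccc(Cl)o3)cc(-c3ccsc3)n2)cc1`) gives an actual number in this assay, 8410 nM.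

Compound 4 (`Cc1ccc(-c2cc(-c3ccc(Cl)o3)cc(-c3ccsc3)n2)cc1`) differs from compound 3 in one place: 4-methylphenyl in place of 5-methylfuran-2-yl on an aromatic carbon. Here 4-methylphenyl stands in place of 5-methylfuran-2-yl on an aromatic carbon, next to the ring nitrogen.

Two measured steps at this same place bear on the change. Putting 4-chlorophenyl in place of furan-2-yl gave an at least 5.9-fold lower number from compound 1 to compound 2 (0.77 log units; beyond the scatter), and putting 5-methylfuran-2-yl in place of 4-chlorophenyl gave an at least 5.9-fold higher number from compound 2 to compound 3 (0.77 log units; beyond the scatter). Both steps lie beyond the scatter, and both favour the six-membered aromatic ring of carbon only, which compound 4 shares with compound 2. The swap of 4-chlorophenyl for 4-methylphenyl itself has not been measured, so some uncertainty remains. A move toward stronger inhibition is therefore expected, with an estimated step of an at least 4.1-fold lower number from compound 3 to compound 4 (0.61 log units; beyond the scatter). The estimate for compound 4 is 12000 nM, with an expected range from 4000 nM to 40000 nM.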

Compound 4, half-maximal inhibitory concentration: 16200 nM
The estimate for compound 4 lay 1.4-fold (0.13 log units) below the measured number; the range from low to high includes it.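

In this assay, the carbon-only ring at this place now lifts a second compound off the limit: the methyl-bearing version gives an at least 3.0-fold lower number from compound 3 to compound 4 (0.48 log units; beyond the scatter), and against the plain furan-2-yl it gives an at least 3.0-fold lower number from compound 1 to compound 4 (0.48 log units; beyond the scatter). The gain therefore does not depend on the chloro group of compound 2, since methyl in place of chloro gives a 1.9-fold higher number from compound 2 to compound 4 (0.28 log units; within the scatter), and so compound 2 and compound 4 cannot be told apart on this read-out. Among these four compounds, the two with a six-membered aromatic ring of carbon only give actual numbers and the two with a furan ring at this place give only a limit, and no compound goes against that split: the limit of > 50000 nM in this assay, at which 2 of the 4 values shown sit.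

Going by these compounds, how far the two furan compounds really lie from compound 2 and compound 4 stays unknown, since a limit gives a bound and no number. Also open, on these data alone, is whether the ring needs a group at all, which a phenyl with no group on it would show, and whether an amine or a carboxylic acid in place of the methyl or chloro would keep this level of inhibition.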